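The source may report more compounds than this note shows. Statements on the series, on what has been measured and on what is new or still open speak of the compounds shown alone.

Measured compounds:
Compound 1 `O=C(CN1CCCC1)N1CCC(NS(=O)(=O)c2cc(S(=O)(=O)c3ccccc3)ccc2C(F)(F)F)CC1` gives 25000 nM in a physicochemical assay for solubility; a higher number here means a more soluble compound, a lower number a less soluble compound.
Compound 2 `CN(C)c1ccc(C(=O)N2CCC[C@H]2C(=O)N2CCC(NS(=O)(=O)c3cc(S(=O)(=O)c4ccccc4)ccc3C(F)(F)F)CC2)cc1` gives 100000 nM in this assay.

Among the measured compounds shown here, of the two numbers so far, compound 2 stands highest; its nearest neighbour is compound 1, whose number lies a clear step lower, beyond the usual scatter. Compound 3 `O=C([C@@H]1CCCN1Cc1ccccc1)N1CCC(NS(=O)(=O)c2cc(S(=O)(=O)c3ccccc3)ccc2C(F)(F)F)CC1` has not yet been measured. Relative to compound 2, the change is benzyl in place of (4-(dimethylamino)phenyl)carbonyl on an amine nitrogen in a ring. For the measured compounds named here, no measured pair shows a change of this kind, so the size of the step can only be estimated. A moderate move downward in this assay is expected, because compound 1 gives 25000 nM, a lower number than compound 2 with a different group in this region of the shared core. The step expected is a 2.5-fold lower number from compound 2 to compound 3 (0.40 log units; beyond the scatter). Compound 3 is therefore estimated at 40000 nM, with a range from 12000 nM to 130000 nM.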

Compound 3, solubility: 25000 nM
Estimate against measurement, compound 3: 1.6-fold (0.20 log units) above, and the stated range covers the measured number.
By their numbers in this assay, from the lowest: compounds 1 and 3 (each within the scatter of the next); then compound 2.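

In this assay, among the compounds shown here, putting benzyl in place of (4-(dimethylamino)phenyl)carbonyl on the amine nitrogen in the five-membered ring gives a 4.0-fold lower number from compound 2 to compound 3 (0.60 log units; beyond the scatter) at this position, where no earlier pair offered a reading. The group that leaves holds a carbonyl and a dimethylamino group, and benzyl holds neither. Setting 1-benzylpyrrolidin-2-yl in place of (pyrrolidin-1-yl)methyl on a carbonyl carbon gives no change at the digits printed from compound 1 to compound 3 (within the scatter) and so does not separate these two groups, while nothing at hand explains either step.

The compounds shown do not tell whether the carbonyl, the dimethylamino group or both together go with the higher number of compound 2, which a plain benzoyl group on the same nitrogen could help to settle. They also leave open how a carboxylic acid or a primary amine on the benzyl ring would read.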